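Swapping Fluoro for Cyclopentylcarbamoyl in an Antiproliferative Series

The source may hold more compounds than are shown below. What is called first, only, known or untested is meant among the compounds shown, and "the series" means these compounds.

Three compounds built on a shared core have been examined in a functional assay on K562 cells (Homo sapiens) for antiproliferative activity, read by CCK-8 assay, with a stated time of 72 h; on this read-out higher numbers stand for weaker inhibition of growth and lower numbers for stronger inhibition of growth. Compound 1 (`CCC1C(=O)N(C)c2cnc(Nc3ccc(S(=O)(=O)NCCO)cc3)nc2N1c1ccn(C)n1`) was reported as "not active" (no number reported), without a number. Compound 3 (`CC[C@@H]1C(=O)N(C)c2cnc(Nc3ccc(S(=O)(=O)NCCO)cc3)nc2N1C1CCCC1`) gives 546 nM. Compound 2 (`CCC1C(=O)N(C)c2cnc(-n3ccc4cc(F)ccc43)nc2N1c1ccn(C)n1`) gives 6070 nM, the higher of the two numbers and therefore the weaker inhibition of growth, and its gap to compound 3 lies beyond the usual scatter. Among the compounds with values here, compounds 2 and 3 differ in more than one place, so no measured pair isolates a single change.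

Compound 4 (`CCC1C(=O)N(C)c2cnc(-n3ccc4cc(C(=O)NC5CCCC5)ccc43)nc2N1c1ccn(C)n1`) departs from compound 2 in one place only: cyclopentylcarbamoyl in place of fluoro on an aromatic carbon. Cyclopentylcarbamoyl takes the place of fluoro on an aromatic carbon of a six-membered aromatic ring of carbon only, part of a fused or bridged system of two rings. Within the data shown here, no measured pair shows what this replacement does, so any expectation remains loose. Compound 3, at 546 nM, shows only that lower numbers occur among these compounds, while compound 1 shows that a numerical result is not assured. A moderate move towards stronger inhibition is expected, and the estimated change is a 2.4-fold lower number from compound 2 to compound 4 (0.39 log units; beyond the scatter). For compound 4 the estimated value is 2500 nM, with an expected range of 400 nM to 12000 nM.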

Compound 4, concentration for 50% growth inhibition: 31300 nM
Beside the measured number, compound 4's estimate is 13-fold (1.10 log units) below it; measured number above the stated range.
By their numbers in this assay, from the lowest: compound 3; then compound 2; then compound 4.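

In this assay the replacement at this aromatic carbon gives the series its first measured single change: a 5.2-fold higher number from compound 2 to compound 4 (0.71 log units; beyond the scatter), a move towards weaker inhibition of growth. The earlier compounds shown here could not isolate any one position, whereas this step shows that the position is not indifferent to what it carries. Of the two groups compared on this six-membered aromatic ring, fluoro goes with the lower number and cyclopentylcarbamoyl with the higher, and no measurement shown accounts for the difference between them.

The compounds shown leave open whether the higher number belongs to the carbamoyl link or to the cyclopentyl ring, and whether an unsubstituted carbamoyl group, a simple amine or a carboxylic acid on the same aromatic carbon would fall nearer to compound 2 or to compound 4. They also leave open whether this replacement would move the number in the same direction and by a similar size if the other groups on the shared core were different.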